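This account rests on a few compounds, and the source may have more. Where it says the series, first, only, none or still open, it means among the compounds named here.

Measured compounds: compound 1 `COc1cc(-c2nnc(S(=O)(=O)C3CCC3)[nH]2)ccc1-c1cnc(OCC(C)C)c(Cl)c1` with 61 uL/min; compound 2 `CC(C)COc1ncc(-c2cc(F)c(-c3nnc(S(=O)(=O)C4CCC4)[nH]3)cc2F)cc1Cl` with 62 uL/min.

Both values come from an ADME assay on microsomes from liver (Rattus norvegicus) for metabolic stability; on this read-out higher numbers stand for fast clearance and lower numbers for slow clearance. The value of compound 2 sits alongside that of compound 1, and the gap between the two falls within the usual scatter, so the two compounds cannot be told apart on this assay. Compound 3 `COc1cc(-c2nnc(S(=O)(=O)C3CCC3)[nH]2)c(F)cc1-c1cnc(OCC(C)C)c(Cl)c1` differs from compound 2 in one place: methoxy in place of fluoro on an aromatic carbon. Since compound 1 already carries a methoxy on that ring and gives 61 uL/min, no step beyond the scatter is expected, and the step of a 1.0-fold lower number from compound 2 to compound 3 (0.01 log units; within the scatter) is estimated to be negligible. Compound 3 is expected to give about 60 uL/min, within 35 uL/min to 105 uL/min.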

Compound 3, intrinsic clearance in a liver preparation (reported as CLH), per the amount of preparation that the assay uses: 27 uL/min
Beside the measured number, compound 3's estimate is 2.2-fold (0.35 log units) above it, and the stated range ends above it.
By their numbers in this assay, from the lowest: compound 3; then compounds 1 and 2 (each within the scatter of the next).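

Replacing fluoro with methoxy at this position, ortho to a large group and para to a fluoro group, is not a neutral change in this assay: it gives a 2.3-fold lower number from compound 2 to compound 3 (0.36 log units; beyond the scatter). The methoxy-bearing ring also responds to added fluoro, which gives a 2.3-fold lower number from compound 1 to compound 3 (0.35 log units; beyond the scatter), so compound 3, carrying both groups, reads lower than either neighbour.

The compounds shown leave open whether an ethoxy group or an amine at this position would give a similar step. Nothing available here bears on the reason for either step.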